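The source may hold more compounds than are shown below. What is called first, only, known or untested is meant among the compounds shown, and "the series" means these compounds.

Measured compounds:
compound 1 `Nc1nc(Nc2ccc(N3CCN(C4CC5CCC4C5)CC3)cc2)nn1-c1ncnc2ccsc12`: 21 nM
compound 2 `Nc1nc(Nc2ccc(N3CCN(C4CC5CCC4C5)CC3)c(F)c2)nn1-c1ncnc2ccsc12`: 20 nM

In an assay on HeLa cells for inhibition of tyrosine-protein kinase receptor UFO (Homo sapiens), read by Western blot, with a stated time of 1 h (a lower number here means that less compound is needed, a higher number that more compound is needed for the effect), compound 1 gives 21 nM and compound 2 gives 20 nM. Within the data shown here, the only step in the set, a 1.1-fold lower number from compound 1 to compound 2 (0.02 log units; within the scatter), is a fluoro in place of hydrogen on an aromatic carbon and does not move the number; compound 2 and compound 1 therefore sit within the scatter of each other, and neither can be called the stronger.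

Compound 3 `Cc1csc2c(-n3nc(Nc4ccc(N5CCN(C6CC7CCC6C7)CC5)c(F)c4)nc3N)ncnc12` is not yet measured. It differs from compound 2 by methyl in place of hydrogen on an aromatic carbon. Among the measured compounds shown here, no measured step touches the fused ring system that carries this change, so there is nothing in the set that bears directly on it. For the measured compounds named here, the one step that exists, a 1.1-fold lower number from compound 1 to compound 2 (0.02 log units; within the scatter), shows that a small substituent added to an aromatic carbon elsewhere leaves this assay unchanged. On that basis the expectation for compound 3 is a step of a 1.3-fold higher number from compound 2 to compound 3 (0.10 log units; within the scatter), that is no movement beyond the scatter, with the range kept wide because the change sits on a part of the core for which no comparison exists. Compound 3 is estimated at 25 nM, between 8 nM and 80 nM.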

Compound 3, half-maximal effective concentration: 62 nM
Beside the measured number, compound 3's estimate is 2.5-fold (0.39 log units) below it; the measured number falls inside the stated range.
By their numbers in this assay, from the lowest: compounds 2 and 1 (each within the scatter of the next); then compound 3.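

Among these compounds, the methyl on an aromatic carbon of the five-membered aromatic ring with 1 sulfur, two ring bonds from the ring sulfur, gives the only step in the set that lies beyond the scatter in this assay (a 3.1-fold higher number from compound 2 to compound 3 (0.49 log units; beyond the scatter)). The fluoro in place of hydrogen on an aromatic carbon elsewhere in the molecule stayed within the scatter (a 1.1-fold lower number from compound 1 to compound 2 (0.02 log units; within the scatter)), so among these compounds a small addition to an aromatic carbon is not neutral everywhere, and this position of the core responds to a single added carbon, though only modestly. No measured information bears on the reason for this rise in the number.

The compounds shown leave open whether the size of the step follows the size of the group at this carbon, as an ethyl, a chlorine, a methoxy or an amine in place of the methyl would show. They also leave open whether the methyl gives a step of similar size on the core of compound 1, which carries hydrogen in place of the fluoro.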